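The compounds below may be only part of what the source reports. "The series", "measured", "known", "first", "only" and "open" are said of these compounds alone.

Compound 1 `CCOCCOn1c(-c2cccc(C#N)c2)nc(C)c1C(=O)OCC` gives 6250 nM
Compound 2 `CCOC(=O)COn1c(-c2cccc(C#N)c2)nc(C)c1C(=O)OCC` gives 6800 nM
Compound 3 `CCOC(=O)c1c(C)nc(-c2cccc(C#N)c2)n1OCc1ccncc1` gives 6200 nM

In a functional assay on a cell-free system (plasma, Oryctolagus cuniculus) for inhibition, with stated times of 5 min, 1 min and 6 min (on this read-out higher numbers stand for weaker inhibition and lower numbers for stronger inhibition), these three compounds cannot be told apart, so compound 3 stands level with the other two. Compound 4 `CCOC(=O)c1c(C)nc(-c2cccc(C#N)c2)n1OCc1ccccc1F` is still to be measured. It carries 2-fluorophenyl in place of pyridin-4-yl on a saturated chain carbon bound to an oxygen on an aromatic ring.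

For the measured compounds named here, all the measured steps bear on this change, since they swap groups at the same place. They are a 1.1-fold higher number from compound 1 to compound 2 (0.04 log units; within the scatter), a 1.0-fold lower number from compound 1 to compound 3 (0.00 log units; within the scatter) and a 1.1-fold lower number from compound 2 to compound 3 (0.04 log units; within the scatter). Three quite different groups therefore gave no step beyond the scatter. Going by the values given here, none of the measured compounds has a carbon-only aromatic ring or a fluorine at this place, so the range has to stay wide. The expected change is a 1.1-fold lower number from compound 3 to compound 4 (0.05 log units; within the scatter), which means no step beyond the scatter in either direction. For compound 4 the estimated value is 5500 nM, with an expected range of 2500 nM to 11000 nM.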

Compound 4, half-maximal inhibitory concentration: 8990 nM
Compound 4: middle estimate off by 1.6-fold (0.21 log units), on the low side; the measured number falls inside the stated range.
By their numbers in this assay, from the lowest: compounds 3, 1, 2 and 4 (each within the scatter of the next).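

With 2-fluorophenyl on a saturated chain carbon bound to an oxygen on an aromatic ring, this assay shows a 1.5-fold higher number from compound 3 to compound 4 (0.16 log units; within the scatter), a 1.3-fold higher number from compound 2 to compound 4 (0.12 log units; within the scatter) and a 1.4-fold higher number from compound 1 to compound 4 (0.16 log units; within the scatter). For the compounds shown here, this is the first group at this place with an aromatic ring of carbon only and with a fluorine, and replacing pyridin-4-yl, which has a hydrogen-bond acceptor, with this group, which has none, gives no step beyond the scatter, so all four groups now read alike here. Nothing in the available data speaks to what lies behind this flat picture.

From the compounds shown here alone, whether an amine, a carboxylic acid or a longer chain at this place would give a step beyond the scatter remains open. So does the effect of changes elsewhere on the shared core, such as replacing the nitrile.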